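Purine hydroxyalkyl analogs: three inactive compounds and a fourth

The compounds below may be only part of what the source reports. "The series", "measured", "known", "first", "only" and "open" are said of these compounds alone.

Compound 1 `CCCCCCC(CCO)n1cnc2c(N(C)C)ncnc21` gives > 50000 nM in a functional assay on SW480 cells (Homo sapiens) for antiproliferative activity, read by MTT assay, with a stated time of 48 h; a lower number here means a stronger inhibitor, a higher number a weaker inhibitor.
Compound 2 `CCCCCCC(CCO)n1cnc2c(N)ncnc21` gives > 50000 nM in this assay.
Compound 3 `CCCCCCCC(CCO)n1cnc2c(N(C)C)ncnc21` gives > 50000 nM in this assay.

Each of these three values is a limit of the assay, not a measured number: the compounds did not reach half-maximal inhibition at the highest concentration tested. The step that the two limits leave unreadable from compound 1 to compound 2 therefore cannot be read, and the same holds for a step that the two limits leave unreadable from compound 1 to compound 3. The cores of compound 1 and compound 3 differ by methyl in place of hydrogen on a saturated chain carbon, seven bonds along the chain from an aromatic nitrogen; the change from compound 1 to compound 2 is amino in place of dimethylamino on an aromatic carbon.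

Compound 4 `CCCCCCCC(CCO)n1cnc2c(N)ncnc21` has not yet been measured. It differs from compound 3 by amino in place of dimethylamino on an aromatic carbon, which is the same change as that from compound 1 to compound 2, at the same place. That earlier change left no readable step because of the limit of > 50000 nM in this assay, at which 3 of the 3 values shown sit. On this basis compound 4 is expected to give 60000 nM in this assay, with 20000 nM and 200000 nM as the expected range, and the expected step that the limit leaves unreadable from compound 3 to compound 4 is one that most likely ends at the limit again, since every value shown so far sits at the limit of > 50000 nM in this assay, at which 3 of the 3 values shown sit.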

Compound 4, half-maximal inhibitory concentration: > 50000 nM
Compound 4: no number, only a limit; the forecaster's own chance of this, stated with the estimate: 85%; the middle value lies beyond the limit too.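

Compound 4 also gives only a limit of the assay, not a number, so no step can be read from compound 3 or compound 2 to compound 4: the limit of > 50000 nM in this assay, at which 4 of the 4 values shown sit.

The compounds shown leave open whether swapping dimethylamino for amino, or adding the methyl on the chain, changes activity at all in this assay once a compound gives a real number.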